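A few compounds are considered here, and "the series" means these few. Any claim that something is new, unique, unknown or untested is made for them only; others in the source may bear on it.

Measured in a functional assay, with a stated time of 90 s; on this read-out higher numbers stand for weaker inhibition and lower numbers for stronger inhibition:
Compound 1 `Cc1nc2c3ccccc3ccc2c2nc3c(ccc4ccccc43)c(-c3cccnc3)c12` gives 156 ug/mL.
Compound 2 `Cc1nc2c3ccccc3ccc2c2nc3c(ccc4ccccc43)c(-c3nccnc3N)c12` gives 134 ug/mL.
Compound 3 `Cc1nc2c3ccccc3ccc2c2nc3c(ccc4ccccc43)c(-c3ccccc3N)c12` gives 125 ug/mL.

The three numbers sit close together. The step from compound 1 to compound 2 is a 1.2-fold lower number from compound 1 to compound 2 (0.07 log units; within the scatter), the step from compound 1 to compound 3 is a 1.2-fold lower number from compound 1 to compound 3 (0.10 log units; within the scatter), and the step from compound 2 to compound 3 is a 1.1-fold lower number from compound 2 to compound 3 (0.03 log units; within the scatter), so compound 3 is separated from each of the other two by less than the usual scatter and the three cannot be told apart on this read-out.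

Compound 4 `Cc1nc2c3ccccc3ccc2c2nc3c(ccc4ccccc43)c(C)c12` differs from compound 3 in one place: methyl in place of 2-aminophenyl on an aromatic carbon. Each of the measured steps exchanged one six-membered aromatic group for another at the same aromatic carbon, and none of them moved the number beyond the scatter. Among the compounds with values here, none of them removed the ring altogether, so no measured step covers the change to methyl. On the shared core, the three aromatic groups gave numbers within the scatter of each other, and the best expectation for compound 4 is therefore a step of about a 1.3-fold higher number from compound 3 to compound 4 (0.11 log units; within the scatter), with a wider range than usual because the change is not matched by any measured pair. Compound 4 is estimated at 160 ug/mL in this assay, between 80 ug/mL and 350 ug/mL.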

Compound 4, half-maximal inhibitory concentration: 195 ug/mL
Compound 4: middle estimate off by 1.2-fold (0.09 log units), on the low side; the measured number falls inside the stated range.
By their numbers in this assay, from the lowest: compounds 3, 2, 1 and 4 (each within the scatter of the next).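

Replacing the ring with methyl at this aromatic carbon, opposite the ring nitrogen, still leaves compound 4 within the scatter of all three others in this assay: the steps are a 1.6-fold higher number from compound 3 to compound 4 (0.19 log units; within the scatter) for the change from 2-aminophenyl, a 1.5-fold higher number from compound 2 to compound 4 (0.16 log units; within the scatter) for the change from 3-aminopyrazin-2-yl and a 1.3-fold higher number from compound 1 to compound 4 (0.10 log units; within the scatter) for the change from pyridin-3-yl. The earlier compounds only exchanged one six-membered aromatic group for another, whereas these steps show that, among these four compounds, neither the aromatic ring nor the hydrogen-bond donor of 2-aminophenyl is needed to keep the number within the scatter. Nothing measured here bears on why the read-out stays flat across these groups.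

On these data alone, whether a longer chain such as n-butyl, a carboxylic acid or a simple amine on this carbon would move the number beyond the scatter remains open. Also open, as far as these compounds go, is whether any group at this position can bring the number well below those of the four compounds, or whether changes elsewhere on the shared core would matter more.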